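The compounds below may be only part of what the source reports. "The series", "measured", "known", "first", "only" and "open" are said of these compounds alone.

Values measured in a functional assay on HepG2 cells (Homo sapiens) for antiproliferative activity, read by sulforhodamine B assay, with a stated time of 48 h; a higher number here means a weaker inhibitor, a lower number a stronger inhibitor:
- Compound 1 `COc1ccc(/C=C/C(=O)c2ccccc2-c2ccc(OC)c(OC)c2)cc1OC`: 3200 nM
- Compound 2 `COc1ccc(/C=C/C(=O)c2ccccc2-c2ccc(F)cc2)cc1OC`: 95 nM
- Compound 3 `COc1ccc(/C=C/C(=O)c2ccccc2-c2cccc(F)c2)cc1`: 110 nM

Compound 3, at 110 nM, lies within the scatter of compound 2, at 95 nM, and both values stand well under that of compound 1. Compound 4 `COc1ccc(/C=C/C(=O)c2ccccc2-c2cccc(F)c2)cc1OC` differs from compound 3 by methoxy in place of hydrogen on an aromatic carbon, ortho to a methoxy group. For the measured compounds named here, the only measured step, a 34-fold lower number from compound 1 to compound 2 (1.53 log units; beyond the scatter), is large, but it concerns a different place and does not size this change. Compound 2, at 95 nM, already carries the entering methoxy group, so no step beyond the scatter is expected in this assay. The estimated change is a 1.1-fold lower number from compound 3 to compound 4 (0.04 log units; within the scatter). For compound 4 the expected value is 100 nM, with an estimated range of 35 nM to 300 nM.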

Compound 4, half-maximal inhibitory concentration: 150 nM
Compound 4: the middle estimate sits 1.5-fold (0.18 log units) below what was measured; the measured number falls inside the stated range.
By their numbers in this assay, from the lowest: compounds 2, 3 and 4 (each within the scatter of the next); then compound 1.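

In this assay the ring position ortho to a methoxy group accepts methoxy in place of hydrogen with a 1.4-fold higher number from compound 3 to compound 4 (0.13 log units; within the scatter) and so with no step beyond the scatter. The fluorine's place on the other ring also stays within the scatter, as 3-fluorophenyl in place of 4-fluorophenyl gives a 1.6-fold higher number from compound 2 to compound 4 (0.20 log units; within the scatter) while 3-fluorophenyl in place of 3,4-dimethoxyphenyl gives a 21-fold lower number from compound 1 to compound 4 (1.33 log units; beyond the scatter) and so matches the large gain seen with 4-fluorophenyl. Nothing available explains these steps. On these data alone, how an amine or an ethoxy group would read at this ring position stays open.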